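The source may report more compounds than this note shows. Statements on the series, on what has been measured and on what is new or still open speak of the compounds shown alone.

Measured in a functional assay on MCF7 cells (Homo sapiens) for antiproliferative activity, read by sulforhodamine B assay, with a stated time of 48 h; on this read-out higher numbers stand for weaker inhibition and lower numbers for stronger inhibition:
- compound 1 `COc1cccc(/C=C/C(=O)C(=Cc2ccc(F)cc2)C(=O)/C=C/c2cccc(OC)c2OC)c1OC`: 1830 nM
- compound 2 `COc1cc(C=C(C(=O)/C=C/c2cccc(OC)c2OC)C(=O)/C=C/c2cccc(OC)c2OC)ccc1O`: 480 nM

Of the two, compound 2 holds the lower number, at 480 nM. Compound 3 `COc1ccc(C=C(C(=O)/C=C/c2cccc(OC)c2OC)C(=O)/C=C/c2cccc(OC)c2OC)cc1OC` has not yet been measured in this assay. It differs from compound 2 by a single change, (methyl in place of hydrogen on an oxygen on an aromatic ring), which turns 4-hydroxy-3-methoxyphenyl into 3,4-dimethoxyphenyl.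

Among the compounds with values here, only one measured step bears on this group: a 3.8-fold lower number from compound 1 to compound 2 (0.58 log units; beyond the scatter), with 4-hydroxy-3-methoxyphenyl entering in place of 4-fluorophenyl. Within the data shown here, that step replaces the whole group, so it does not isolate hydroxy to methoxy, and no measured pair does. Among the measured compounds shown here, it shows only that the group carrying the hydroxy goes with the lower number. Compound 3 keeps the same place on the shared core but loses that hydroxy, so a small move toward a higher number in this assay is expected, smaller than the step seen from compound 1 and perhaps not beyond the scatter.

The expected change is a 1.5-fold higher number from compound 2 to compound 3 (0.16 log units; within the scatter). For compound 3 the estimated value is 700 nM, with an expected range from 250 nM to 1900 nM.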

Compound 3, half-maximal inhibitory concentration: 560 nM
Compound 3: the middle estimate sits 1.3-fold (0.10 log units) above what was measured; the measured number falls inside the stated range.
By their numbers in this assay, from the lowest: compounds 2 and 3 (each within the scatter of the next); then compound 1.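

In this assay, within the data shown here, this is the first pair that isolates hydroxy to methoxy on 4-hydroxy-3-methoxyphenyl, and it gives a 1.2-fold higher number from compound 2 to compound 3 (0.07 log units; within the scatter). A methyl in place of hydrogen on this oxygen therefore leaves the number within the scatter, so the hydroxy itself is not required for a value in this range on the shared core. The 3,4-dimethoxyphenyl group also keeps a gap from 4-fluorophenyl beyond the scatter, with a 3.3-fold lower number from compound 1 to compound 3 (0.51 log units; beyond the scatter), which shows that the earlier gap from 4-fluorophenyl does not depend on the hydrogen on that oxygen. No measurement shown here offers an explanation for either step.

The compounds shown leave open how an ethyl group or a longer chain on this oxygen would read in this assay, and whether an amine in place of the hydroxy would keep the number in the same range. They also leave open how an unsubstituted phenyl would compare at this place, which would show how much of the gap from 4-fluorophenyl belongs to the two oxygen-bearing groups together.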